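The compounds below may be only part of what the source reports. "The series", "measured", "known", "first", "only" and "open" are said of these compounds alone.

Measured in a functional assay on MCF7 cells (Homo sapiens) for cytotoxicity, read by MTT assay, with a stated time of 96 h; a higher number here means a weaker inhibitor, a lower number a stronger inhibitor:
- compound 1 `COc1cc(C(=O)c2cn(-c3ccccc3C)cc2-c2ccccc2)cc(OC)c1OC`: 2200 nM
- compound 2 `COc1cc(C(=O)c2cn(-c3ccc(Br)cc3)cc2-c2ccccc2)cc(OC)c1OC`: 20 nM
- compound 3 `COc1cc(C(=O)c2cn(-c3ccccc3)cc2-c2ccccc2Cl)cc(OC)c1OC`: 76 nM

Of these three numbers, compound 3 at 76 nM is the second highest. Compound 4 `COc1cc(C(=O)c2cn(-c3ccccc3)cc2-c2cccc([N+](=O)[O-])c2)cc(OC)c1OC` has not been measured yet. It differs from compound 3 by 3-nitrophenyl in place of 2-chlorophenyl on an aromatic carbon. Among the measured compounds shown here, the only measured step, a 110-fold lower number from compound 1 to compound 2 (2.04 log units; beyond the scatter), is large but lies on an aromatic nitrogen. For the measured compounds named here, no measured step covers this carbon, so direction rests on judgement, while that step argues for a wide range. A moderate rise in this assay is expected, with an estimated 2.6-fold higher number from compound 3 to compound 4 (0.42 log units; beyond the scatter). For compound 4 the expected value is 200 nM, with an estimated range of 40 nM to 1000 nM.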

Compound 4, half-maximal inhibitory concentration: 50 nM
Compound 4: middle estimate off by 4.0-fold (0.60 log units), on the high side; the range from low to high includes it.
By their numbers in this assay, from the lowest: compound 2; then compounds 4 and 3 (each within the scatter of the next); then compound 1.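

In this assay, 3-nitrophenyl in place of 2-chlorophenyl on this aromatic carbon gives a 1.5-fold lower number from compound 3 to compound 4 (0.18 log units; within the scatter) and so leaves the two compounds within the scatter. Among the compounds shown here, this is the first step read at this carbon, which carries either group with no readable change, whereas the only earlier step lay on the aromatic nitrogen. No measured evidence bears on this result.

The step changes both the substituent and its place on the phenyl ring, so neither can be read alone. On these data alone, whether an amine or a carboxylic acid on that phenyl ring would also leave the value within the scatter remains open.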